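The compounds below may be only part of what the source reports. "The series", "measured", "known", "first", "only" and "open" are said of these compounds alone.

In a functional assay on MCF7 cells (Homo sapiens) for inhibition, read by MTT assay, with a stated time of 72 h (on this read-out lower numbers stand for stronger inhibition and higher numbers for weaker inhibition), compound 1 `O=C(Nc1ccccc1)C1CCN(C/C=C/c2ccccc2)CC1` gives 60200 nM and compound 2 `Cc1ccc(NC(=O)C2CCN(C/C=C/c3ccccc3)CC2)cc1` gives 30000 nM while compound 3 `CCCCc1ccc(NC(=O)C2CCN(C/C=C/c3ccccc3)CC2)cc1` gives 5870 nM as the lowest number. Compound 2 stands second highest of the three. Next is compound 4 `COc1cccc(NC(=O)C2CCN(C/C=C/c3ccccc3)CC2)c1` with this change: 3-methoxyphenyl in place of 4-methylphenyl on an amide-type nitrogen that is, 3-methoxyphenyl in place of 4-methylphenyl on an amide-type nitrogen. Among the measured compounds shown here, no measured step covers this exchange directly. The methyl step a 2.0-fold lower number from compound 1 to compound 2 (0.30 log units; within the scatter) is the closest guide and is small. The butyl steps a 10-fold lower number from compound 1 to compound 3 (1.01 log units; beyond the scatter) and a 5.1-fold lower number from compound 2 to compound 3 (0.71 log units; beyond the scatter) are larger but involve a longer chain that compound 4 lacks. In this assay no step beyond the scatter is therefore expected, in either direction. The expected step is a 1.1-fold higher number from compound 2 to compound 4 (0.04 log units; within the scatter) and stays within the scatter. For compound 4 the estimate is 33000 nM with an expected range from 14000 nM to 75000 nM as the working figure.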

Compound 4, half-maximal inhibitory concentration: 42700 nM
Compound 4: middle estimate off by 1.3-fold (0.11 log units), on the low side; low and high end bracket the measured number.
By their numbers in this assay, from the lowest: compound 3; then compounds 2, 4 and 1 (each within the scatter of the next).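

In this assay, 3-methoxyphenyl in place of 4-methylphenyl on the amide-type nitrogen gives a 1.4-fold higher number from compound 2 to compound 4 (0.15 log units; within the scatter), and the added methoxy gives a 1.4-fold lower number from compound 1 to compound 4 (0.15 log units; within the scatter). Both steps stay within the scatter, so this first group with a hydrogen-bond acceptor at this position leaves the number unchanged within that scatter, unlike the butyl of compound 3. No supporting data explain this result. Open, on these data alone, is whether a butoxy chain or an amine on the same aromatic ring would follow methoxy or butyl.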